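Compound 2 and the hydroxymethyl swap: working notes

The compounds below may be only part of what the source reports. "The series", "measured", "known", "first", "only" and "open" are said of these compounds alone.

In a functional assay on HL-60 cells (Homo sapiens) for inhibition, read by MTT assay, with a stated time of 72 h, tested at 50 uM (on this read-out higher numbers stand for more inhibition of growth at the one concentration tested and lower numbers for less inhibition of growth), compound 1 (`C=CCc1ccc(OCc2cn(-c3cc(OC)c(OC)c(OC)c3)nn2)c(O)c1`) gives 41.4% and compound 2 (`C=CCc1ccc(OCc2cn(-c3ccccc3Cl)nn2)c(O)c1`) gives 43.2%. These two values lie within the scatter of each other, so neither stands apart. The next compound is compound 3 (`C=CCc1ccc(OCc2cn(-c3ccccc3CO)nn2)c(O)c1`), with hydroxymethyl in place of chloro on an aromatic carbon, ortho to a large group: hydroxymethyl in place of chloro on an aromatic carbon.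

Within the data shown here, no measured step isolates this change. Among the measured compounds shown here, the only guide is the gap between compound 2 and compound 1 at 41.4%, which lies within the scatter although the two differ in substitution on that aromatic ring. A small downward move, not clearly beyond the scatter, is expected, with the estimated step being a number 7.2 percentage points lower from compound 2 to compound 3 (within the scatter). In this assay, the expected value for compound 3 is 36%, with an estimated range of 22% to 50%.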

Compound 3, percent growth inhibition at one concentration: 47.1%
The estimate for compound 3 lay 11.1 percentage points below the measured number; measured number inside the range.
By their numbers in this assay, from the lowest: compounds 1, 2 and 3 (each within the scatter of the next).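

In this assay, among these compounds, the change from 2-chlorophenyl to 2-(hydroxymethyl)phenyl gives a number 3.9 percentage points higher from compound 2 to compound 3 (within the scatter) and provides the first measured step that isolates this position, on an aromatic carbon, ortho to a large group. Within this pair, a chloro with no hydrogen-bond donor or acceptor can give way to a hydroxymethyl with one of each, and the read-out stays within the scatter at the single concentration tested. Nothing available gives a reason for this outcome, and the step alone cannot supply one.

The compounds shown leave open how an aminomethyl group, a carboxylic acid or a longer chain such as hydroxyethyl would read at the same place. They also leave open whether this step would stay within the scatter across a full concentration range.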